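This account rests on a few compounds, and the source may have more. Where it says the series, first, only, none or still open, it means among the compounds named here.

Of the compounds shown here, two have so far been measured in a functional assay on L02 cells (Homo sapiens) for inhibition, read by MTT assay, with a stated time of 72 h; a higher number here means a weaker inhibitor, a lower number a stronger inhibitor. Compound 1 `C=C(c1ccc(F)c(F)c1)C1COC2(CCCCC2)OO1` gives 16500 nM in this assay and sits at the low end of the two numbers, but compound 2 `C=C(c1ccc(Cl)c(Cl)c1Cl)C1COC(C)(C)OO1` gives 18100 nM, a number within the scatter of compound 1, so the two cannot be told apart. Compound 3 `C=C(c1ccc(OC)c(F)c1)C1COC2(CCCCC2)OO1` has not yet been measured. It differs from compound 1 in one place: methoxy in place of fluoro on an aromatic carbon. Among the compounds with values here, no measured pair shows what this exchange does on its own, so the size of the step is uncertain; the two measured compounds, which differ from each other in more than one place, give numbers within the scatter of each other and offer no pointer toward a large shift. The step from compound 1 to compound 3 is expected to be small, close to the scatter, a 1.1-fold higher number from compound 1 to compound 3 (0.04 log units; within the scatter). Compound 3 is therefore estimated at 18000 nM, with a range from 8000 nM to 45000 nM.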

Compound 3, half-maximal inhibitory concentration: 15400 nM
Estimate against measurement, compound 3: 1.2-fold (0.07 log units) above; the measured number falls inside the stated range.
By their numbers in this assay, from the lowest: compounds 3, 1 and 2 (each within the scatter of the next).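

In this assay, within the data shown here, methoxy in place of fluoro on an aromatic carbon gives a 1.1-fold lower number from compound 1 to compound 3 (0.03 log units; within the scatter) as the first direct reading of this exchange. At this position, ortho to a fluoro group and para to a large group, a group of 2 heavy atoms with 1 hydrogen-bond acceptor thus stands in for a group of 1 heavy atom with 0 hydrogen-bond acceptors, and the assay does not tell compound 1 and compound 3 apart. No independent measurement bears on why this exchange leaves the two compounds within the scatter.

Going by these compounds, whether an amine, a carboxylic acid or a longer chain such as butoxy at this position would move the number beyond the scatter remains open. Also open, on these data alone, is whether the same exchange would give a similar step on any core other than that of compound 1.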